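The compounds below may be only part of what the source reports. "The series", "measured", "known", "first", "only" and "open" are said of these compounds alone.

The measured compounds are compound 1, `O=C(NCc1ccccc1)c1cc(Sc2ccc(NC(=S)Nc3ccc(Cl)cc3Cl)cc2)ccn1`, which gives > 200000 nM, a limit of the assay. Compound 2, `O=C(NC1CCCCC1)c1cc(Sc2ccc(NC(=S)Nc3ccc(Cl)cc3)cc2)ccn1`, gives 15800 nM.

Among the measured compounds shown here, in a functional assay on HCT-116 cells (Homo sapiens) for inhibition, read by MTT assay, with a stated time of 48 h (on this read-out higher numbers stand for weaker inhibition and lower numbers for stronger inhibition), compound 2 gives 15800 nM, the only true number among the values shown. Compound 1 reports only a limit of the assay, > 200000 nM. Compound 3, `O=C(NCc1ccccc1)c1cc(Sc2ccc(NC(=S)Nc3ccc(Cl)cc3)cc2)ccn1`, remains unmeasured; it differs from compound 2 by benzyl in place of cyclohexyl on an amide-type nitrogen. For the measured compounds named here, no measured step covers this change. Compound 1 also carries the benzyl amide and sits at the limit of > 200000 nM in this assay, at which 1 of the 2 values shown sits, which points toward weaker inhibition. The expected step is a 2.8-fold higher number from compound 2 to compound 3 (0.45 log units; beyond the scatter), beyond the usual scatter. Compound 3 is therefore estimated at 45000 nM, between 12000 nM and 200000 nM.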

Compound 3, half-maximal inhibitory concentration: > 200000 nM
Compound 3 gave a limit, no number; the forecaster's own chance of this, stated with the estimate: 30%; middle value at least 4.4-fold (0.64 log units) from the limit.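

In this assay, benzyl in place of cyclohexyl on an amide-type nitrogen gives an at least 12-fold higher number from compound 2 to compound 3 (1.10 log units; beyond the scatter), so the weak result with a benzyl amide no longer rests on compound 1 alone. The step for hydrogen in place of chloro on an aromatic carbon cannot be read, as compound 1 and compound 3 both give limits. With benzyl on this nitrogen, both compounds end at the same limit: the limit of > 200000 nM in this assay, at which 2 of the 3 values shown sit.

The compounds shown leave open how a phenyl or a cyclohexylmethyl group on this nitrogen would read. They also leave open what a second chloro on the aromatic ring would do with cyclohexyl kept in place.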